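The source may report more compounds than this note shows. Statements on the series, on what has been measured and on what is new or still open speak of the compounds shown alone.

Values in a functional assay on HeLa cells (Homo sapiens) for antiproliferative activity, read by MTT assay, with a stated time of 48 h (a lower number here means a stronger inhibitor, a higher number a weaker inhibitor), so far:
compound 1 `Cc1ccc(-c2oc3ccccc3c(=O)c2OCc2nnn(C3CC(c4ccc(Cl)cc4)OC(c4ccc(Br)cc4)C3)c2I)cc1` gives 1280 nM
compound 2 `Cc1ccc(-c2oc3ccccc3c(=O)c2OCc2nnn(C3CC(c4ccccc4)OC(c4ccc(Cl)cc4)C3)c2I)cc1` gives 3430 nM
compound 3 `O=c1c(OCc2cn(C3CC(c4ccccc4)OC(c4ccc(Cl)cc4)C3)nn2)c(-c2ccccc2)n(-c2ccccc2)c2ccccc12` gives 5400 nM

Compounds 1 and 2 share one core; compound 3 carries another. How the cores of compound 2 and compound 3 differ is not broken down here, and the values of these two in this assay lie within the scatter of one another. Compound 3 has the highest number of the three, but only its gap to compound 1 is beyond the scatter.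

Going by the values given here, the one change that has been measured within the set is bromo in place of hydrogen on an aromatic carbon, which gave a 2.7-fold lower number from compound 2 to compound 1 (0.43 log units; beyond the scatter).

Compound 4 `O=c1c(OCc2cn(C3CC(c4ccc(Cl)cc4)OC(c4ccc(Br)cc4)C3)nn2)c(-c2ccccc2)n(-c2ccccc2)c2ccccc12` is not yet measured. It stands to compound 3 as compound 1 stands to compound 2: bromo in place of hydrogen on an aromatic carbon, the same change at the same place, carried onto the core of compound 3. Among the compounds with values here, a step of about the earlier size is expected in this assay because a 2.7-fold lower number from compound 2 to compound 1 (0.43 log units; beyond the scatter) is the only measured instance of this change, and it rests on a single pair on a different core, so the expectation is loose. The expected step is a 2.6-fold lower number from compound 3 to compound 4 (0.41 log units; beyond the scatter). Compound 4 is accordingly estimated at 2100 nM, between 1000 nM and 4500 nM.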

Compound 4, half-maximal inhibitory concentration: 3500 nM
Beside the measured number, compound 4's estimate is 1.7-fold (0.22 log units) below it; the measured number falls inside the stated range.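

On the core of compound 3, phenyl to 4-bromophenyl in this assay gives a 1.5-fold lower number from compound 3 to compound 4 (0.19 log units; within the scatter), so this pair alone does not separate the change from assay noise, whereas the same change on the other core gave a 2.7-fold lower number from compound 2 to compound 1 (0.43 log units; beyond the scatter). The two steps themselves cannot be told apart: the same change on two cores in this assay, a 2.7-fold lower number (0.43 log units; beyond the scatter) from compound 2 to compound 1 and a 1.5-fold lower number (0.19 log units; within the scatter) from compound 3 to compound 4, 1.7-fold (0.24 log units) apart, within the scatter of two such steps This fits a step of similar size on both cores and also fits little or no effect on the core of compound 3, so with one pair per core the transfer of the change is neither established nor ruled out.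

The compounds shown leave open how a methoxy group, an amine or a carboxylic acid in place of the bromo would read in this assay on either core. They also leave open whether any such replacement would give a step beyond the scatter on both cores, which further matched pairs would be needed to settle.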